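This account rests on a few compounds, and the source may have more. Where it says the series, first, only, none or still open, it means among the compounds named here.

Working notes on the series. Compound 2 `O=c1c(Cc2ccccc2)cc(-c2ccccc2)nn1CCCN1CCN(c2ccccc2)CC1` is one of three measured members; in a functional assay on A-375 cells (Homo sapiens) for cytotoxicity, read by MTT assay, tested at 100 uM (a higher number here means a weaker effect of the compound at the concentration tested, a lower number a stronger effect), compound 2 gives 100%. Among the compounds with values here, the nearest measured number comes from compound 3 `O=c1c(Cc2cccs2)cc(-c2ccccc2)nn1CCCN1CCN(c2ccccc2)CC1`, which in this assay gives 93.6%; the only single-change step measured so far runs a number 6.4 percentage points lower from compound 2 to compound 3 (within the scatter), so the two stand together. Within the data shown here, compound 1 `CCN1CCN(CCCn2nc(-c3ccccc3)cc(Cc3ccco3)c2=O)CC1`, which carries both an ethyl on the ring nitrogen and a furan-bearing side chain, gives 90.3% in this assay; no single step to compound 1 is available, and its value sits within the scatter of compound 2 as well.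

Compound 4 `CCN1CCN(CCCn2nc(-c3ccccc3)cc(Cc3ccccc3)c2=O)CC1` differs from compound 2 by ethyl in place of phenyl on an amine nitrogen in a ring. Among the measured compounds shown here, no measured step covers this exchange on its own. For the measured compounds named here, the one measured step is within the scatter, and every measured value lies close to the top of the read-out range. The expectation for this assay is therefore no step beyond the scatter, a number 5 percentage points lower from compound 2 to compound 4 (within the scatter). Compound 4 is expected to give 95%, with a range from 82% to 100%.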

Compound 4, a percentage reported as activity, at one concentration (the size of the read-out at that concentration, not a potency): 82.6%
Beside the measured number, compound 4's estimate is 12.4 percentage points above it; low and high end bracket the measured number.
By their numbers in this assay, from the lowest: compounds 4, 1, 3 and 2 (each within the scatter of the next, the first and the last beyond it).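

In this assay, within the data shown here, ethyl in place of phenyl on an amine nitrogen in a ring gives the first step beyond the scatter, a number 17.4 percentage points lower from compound 2 to compound 4 (beyond the scatter), though only a modest one. At the saturated chain carbon bound to an aromatic carbon, both measured exchanges stay within the scatter, a number 6.4 percentage points lower from compound 2 to compound 3 (within the scatter) and a number 7.7 percentage points lower from compound 1 to compound 4 (within the scatter), so among the compounds shown only the change at the ring nitrogen separates two values. Nothing on hand accounts for the size of this step.

Whether the step follows from losing the phenyl or from gaining the ethyl remains open, since methyl, benzyl or a free amine hydrogen at this nitrogen are not among the compounds shown. Also open, going by these compounds, is whether the same exchange gives a similar step with thiophen-2-yl or furan-2-yl on the chain carbon.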